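The compounds below may be only part of what the source reports. "The series", "measured", "known", "first", "only" and "open" are said of these compounds alone.

Series notes, values from a physicochemical assay for solubility, read by HPLC, in phosphate buffer, measured as kinetic solubility, at pH 7.4; a higher number here means a more soluble compound, a lower number a less soluble compound:

- compound 1 `CC(=O)c1cc(-c2ccc(Cl)cc2)n(-c2ccc(S(N)(=O)=O)cc2)c1C`: 2700 nM
- compound 2 `CCOC(=O)c1cc(-c2ccc(F)cc2)n(-c2ccc(S(N)(=O)=O)cc2)c1N`: 7500 nM
- compound 3 `CC(C)(C)C(=O)c1cc(-c2ccc(S(N)(=O)=O)cc2)n(-c2ccc(Cl)cc2)n1`: 6600 nM

Compound 3 at 6600 nM and compound 2 at 7500 nM lie within the scatter of each other. Compound 1 gives 2700 nM. Compound 3 and compound 2 both stand higher than compound 1, and those gaps are beyond the scatter. The three measured compounds differ from one another in more than one place, so their values show no effect of any single change.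

Compound 4 `NS(=O)(=O)c1ccc(-c2cc(C(=O)N3CCCCC3)nn2-c2ccc(Cl)cc2)cc1` has not yet been measured in this assay. It keeps the rest of compound 3 and carries piperidin-1-yl in place of tert-butyl on a carbonyl carbon. The same difference reads as (tert-butyl)carbonyl to (piperidin-1-yl)carbonyl.

Among the compounds with values here, no measured pair shows this change, so the expectation starts from compound 3 at 6600 nM and leans on no trend. The expected step of a 1.1-fold higher number from compound 3 to compound 4 (0.03 log units; within the scatter) is small and stays within the scatter, and its direction is not firmly expected. The range is kept wide, since a single close relative supports it. For compound 4 the estimated value is 7000 nM, with an expected range of 2500 nM to 20000 nM.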

Compound 4, solubility: 65900 nM
For compound 4 the middle estimate is 9.4-fold (0.97 log units) below the measured one, outside the stated range (above it).
By their numbers in this assay, from the lowest: compound 1; then compounds 3 and 2 (each within the scatter of the next); then compound 4.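

In this assay, the series now has its first comparison that differs in only one place: piperidin-1-yl in place of tert-butyl on a carbonyl carbon gives a 10-fold higher number from compound 3 to compound 4 (1.00 log units; beyond the scatter). The group on this carbonyl carbon, whose other neighbour is an aromatic carbon, therefore matters to this read-out, at least on the core of compound 3, even though the two groups count the same for hydrogen-bond donors, hydrogen-bond acceptors and net charge, and differ in heavy atoms, the nitrogen and the six-membered non-aromatic ring. Nothing measured for these compounds accounts for the size of this step.

A single step leaves open whether the rise goes with the ring, with the nitrogen bonded to the carbonyl carbon, or with both; cyclohexyl, dimethylamino or morpholin-4-yl on the same carbonyl carbon would pull these apart. On these data alone, it is also open whether piperidin-1-yl on a carbonyl carbon gives a similar step on the cores of compound 1 and compound 2, which stay unconnected to compound 4 by any single change.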